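Swapping the aminophenyl for a catechol on the ether oxygen

The source may report more compounds than this note shows. Statements on the series, on what has been measured and on what is new or still open speak of the compounds shown alone.

Measured in a functional assay on HeLa cells (Homo sapiens) for inhibition, read by CCK-8 assay, with a stated time of 48 h; on this read-out higher numbers stand for weaker inhibition and lower numbers for stronger inhibition:
compound 1 `Cc1ccc(-c2ccsc2S(=O)(=O)NCCNC(=O)Nc2cc(C(F)(F)F)cc(C(F)(F)F)c2)c(Oc2ccc(O)c(O)c2)c1`: 9700 nM
compound 2 `O=C(NCCNS(=O)(=O)c1ccc(-c2ccccc2O[C@H]2CC[C@@H](O)CC2)s1)Nc1cc(C(F)(F)F)cc(C(F)(F)F)c1`: 14100 nM
compound 3 `Nc1ccc(Oc2ccccc2-c2ccc(S(=O)(=O)NCCNC(=O)Nc3cc(C(F)(F)F)cc(C(F)(F)F)c3)s2)cc1`: > 20000 nM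

Compound 3 gives only a limit, > 20000 nM, and not a number. Compound 4 `O=C(NCCNS(=O)(=O)c1ccc(-c2ccccc2Oc2ccc(O)c(O)c2)s1)Nc1cc(C(F)(F)F)cc(C(F)(F)F)c1` differs from it as follows: 3,4-dihydroxyphenyl in place of 4-aminophenyl on an oxygen on an aromatic ring. In words, 3,4-dihydroxyphenyl stands in place of 4-aminophenyl on an oxygen on an aromatic ring. Within the data shown here, the one measured step at this place, an at least 1.4-fold higher number from compound 2 to compound 3 (0.15 log units; that floor lies within the scatter), says little about the new group. Compound 1 is a closer guide, since it also carries 3,4-dihydroxyphenyl on an otherwise altered core and gives 9700 nM. A modest move toward stronger inhibition is therefore expected, an at least 1.6-fold lower number from compound 3 to compound 4 (0.22 log units; that floor lies within the scatter). Compound 4 is estimated at 12000 nM, with an expected range of 6000 nM to 24000 nM.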

Compound 4, half-maximal inhibitory concentration: > 20000 nM
Compound 4 gave a limit, no number (the forecaster's own chance of this, stated with the estimate: 25%); at least 1.6-fold (0.22 log units) between middle value and limit.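

On the shared core in this assay, 3,4-dihydroxyphenyl on an oxygen on an aromatic ring yields no number, and neither does 4-aminophenyl. Among these compounds, compound 3 and compound 4 sit at the same limit of the assay, so the step between them cannot be read: the limit of > 20000 nM in this assay, at which 2 of the 4 values shown sit. Against 4-hydroxycyclohexyl, the one readable step is an at least 1.4-fold higher number from compound 2 to compound 4 (0.15 log units; that floor lies within the scatter), so these two groups cannot be put in order.

Going by these compounds, how far compound 3 and compound 4 lie past the limit stays open. Also open, on these data alone, is whether a carboxylic acid or a longer alkyl chain on this oxygen would give a measurable value.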